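The compounds below may be only part of what the source reports. "The series", "measured", "known", "first", "only" and "open" are said of these compounds alone.

In a functional assay on MCF7 cells (Homo sapiens) for cytotoxicity, read by MTT assay, with a stated time of 72 h (a higher number here means a weaker inhibitor, a lower number a stronger inhibitor), compound 3 (`CCOC(=O)c1c(C)oc2ncnc(Nc3cccc(OC)c3)c12`) gives only a limit of > 1000000 nM and no number. Compound 1 (`C#Cc1cccc(Nc2ncnc3oc(C)c(C(=O)OCC)c23)c1`) also gives only a limit, > 1000000 nM in this assay. These two results make up the limit of > 1000000 nM in this assay, at which 2 of the 3 values shown sit, and leave compound 3 with no measured potency to start from. For the measured compounds named here, the one measured step on this aromatic carbon is a step that the two limits leave unreadable from compound 1 to compound 3 and offers no size to carry forward.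

Compound 4 (`CCOC(=O)c1c(C)oc2ncnc(Nc3cccc(Cl)c3)c12`) has chloro in place of the methoxy of compound 3, on an aromatic carbon meta to a large group, and the change reads chloro in place of methoxy on an aromatic carbon in counted terms.

Going by the values given here, the only number comes from a compound that differs at a second place. Carrying the same 3-chlorophenyl but with an amide where compound 4 has an ester, compound 2 (`Cc1oc2ncnc(Nc3cccc(Cl)c3)c2c1C(=O)NC(C)C`) gives 191000 nM in this assay. That value is a weak hint, so a modest move towards stronger inhibition is expected. The estimated step is an at least 2.0-fold lower number from compound 3 to compound 4 (0.30 log units; that floor lies within the scatter) and rests on little. For compound 4 the estimate is 500000 nM within an expected range of 150000 nM to 1000000 nM and another limit remains likely.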

Compound 4, half-maximal inhibitory concentration: > 1000000 nM
Compound 4 was reported as a limit; the forecaster's own chance of this, stated with the estimate: 60%; at least 2.0-fold (0.30 log units) between middle value and limit.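

In this assay compound 4 gives > 1000000 nM, which is a limit and not a number. With the 3-chlorophenyl held constant, ethoxy in place of isopropylamino on the carbonyl carbon gives an at least 5.2-fold higher number from compound 2 to compound 4 (0.71 log units; beyond the scatter), so the chloro alone does not bring the value of compound 4 to a measured number, and the group on the carbonyl carbon matters in this series. The steps among compound 1, compound 3 and compound 4 on the aromatic carbon cannot be read, because all three sit at the same limit: the limit of > 1000000 nM in this assay, at which 3 of the 4 values shown sit.

On these data alone, how far compound 4 lies past its limit stays open, so the full size of the carbonyl step is unknown. Also open, as far as these compounds go, is whether cyclopropylamino or a hydroxyl group on that carbonyl carbon would shift the value further, and whether isopropylamino there would give a number alongside the 3-methoxyphenyl.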